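Propyl ester of the inactive acid: expected effect

The compounds below may be only part of what the source reports. "The series", "measured", "known", "first", "only" and "open" are said of these compounds alone.

Measured in a functional assay on the whole organism with Scenedesmus acutus as the target, with a stated time of 20 h; a higher number here means a weaker inhibitor, a lower number a stronger inhibitor
compound 1 `O=C(O)c1cc(N2C(=O)C3=C(CCCC3)C2=O)c(F)cc1Cl` gives 3160 nM
compound 2 `O=C(O)c1cc(N2C(=O)C3=C(CCCC3)C2=O)ccc1Cl` gives > 100000 nM as a limit of the assay

Compound 2 stands only at a limit of the assay (the limit of > 100000 nM in this assay, at which 1 of the 2 values shown sits). Compound 3 `CCCOC(=O)c1cc(N2C(=O)C3=C(CCCC3)C2=O)ccc1Cl` differs from compound 2 at one place (propyl in place of hydrogen on an oxygen next to a carbonyl group): propyl in place of hydrogen on an oxygen next to a carbonyl group, that is, carboxy to propoxycarbonyl. For the measured compounds named here, the one measured step (an at least 31-fold higher number from compound 1 to compound 2 (1.50 log units; beyond the scatter)) is a different change, hydrogen in place of fluoro on an aromatic carbon, so it bears on this change only indirectly. It was large, and it shows that a single replacement on this core moved the number strongly. A large step towards a lower number is therefore expected, although compound 3 may also remain at the limit. The expected step (an at least 16-fold lower number from compound 2 to compound 3 (1.22 log units; beyond the scatter)) is an estimate with wide uncertainty. The estimate for compound 3 is 6000 nM within an expected range (500 nM to 60000 nM).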

Compound 3, half-maximal inhibitory concentration: 661 nM
Estimate against measurement, compound 3: 9.1-fold (0.96 log units) above, within the range that was stated.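

Carboxy to propoxycarbonyl gives an at least 150-fold lower number from compound 2 to compound 3 (2.17 log units; beyond the scatter) in this assay, so the oxygen next to a carbonyl group is a place where one replacement on the shared core moves the number strongly. Until now, the only step shown was hydrogen in place of fluoro on an aromatic carbon, and this result shows that a measured value can be reached without the fluoro when the carboxy group is changed. Compound 2 gives > 100000 nM, which is a limit of the assay and not a number: the limit of > 100000 nM in this assay, at which 1 of the 3 values shown sits.

It remains open whether the effect belongs to propyl or to esters in general, since the compounds shown include no methyl ester, butyl ester or amide at this place. Also open, from the compounds shown here alone, is what propoxycarbonyl does when the fluoro is present on the aromatic ring.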